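This account rests on a few compounds, and the source may have more. Where it says the series, first, only, none or still open, it means among the compounds named here.

Compound 1 `COc1cccc(CNCCCNc2ccnc3cc(C4CCCCC4)ccc23)c1O` has been measured in a physicochemical assay for acid dissociation, where compound 1 gives 9.47. Two related compounds sit beside it: compound 2 `COc1ccc(F)cc1CNCCCNc1ccnc2cc(C3CCCCC3)ccc12` gives 9.47, and compound 3 `COc1ccc(-c2ccc3c(NCCCNCc4ccco4)ccnc3c2)cc1` gives 9.47, so compound 1 stands level with both at the digits shown, the nearest being compound 2 and the furthest compound 3. Among the compounds with values here, the only step between two measured compounds that differ in one place, no change at the digits printed from compound 1 to compound 2 (within the scatter), exchanged the group on the saturated chain carbon bound to an amine nitrogen and left the value unchanged within the scatter.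

Compound 4 `COc1cccc(CNCCCNc2ccnc3cc(Cc4ccccc4)ccc23)c1O` differs from compound 1 at a different spot, on the fused ring system: benzyl in place of cyclohexyl on an aromatic carbon. Within the data shown here, no measured step alters this position, and the one step that exists, from compound 1 to compound 2, was flat. The expectation is therefore no step beyond the scatter, an estimated change of no change at the digits printed from compound 1 to compound 4 (within the scatter). Compound 4 is estimated to give 9.47, in a range from 9.2 to 9.75.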

Compound 4, acid dissociation constant: 9.47
For compound 4 middle estimate and measured number coincide at the digits printed; the measured number falls inside the stated range.
By their numbers in this assay, from the lowest: compounds 1, 2, 3 and 4 (each within the scatter of the next).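

In this assay, benzyl in place of cyclohexyl on this aromatic carbon of the shared core gives no change at the digits printed from compound 1 to compound 4 (within the scatter) and so provides the only step shown at this position, since the earlier step changed a group elsewhere. Here a six-membered non-aromatic ring of carbon only gives way to a six-membered aromatic ring of carbon only, and the reading stays within the scatter. No supporting measurement is available to explain this flat result.

On these data alone, whether an amine, a carboxylic acid or a longer chain on this aromatic carbon would also leave the reading level remains open. As far as these compounds go, it is also open whether benzyl gives the same result when the 5-fluoro-2-methoxyphenyl group of compound 2 is present.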